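Removing a Protecting Group from a Weak Growth Inhibitor

A few compounds are considered here, and "the series" means these few. Any claim that something is new, unique, unknown or untested is made for them only; others in the source may bear on it.

Measured compounds:
Compound 1, `Cc1ccc(NC(=O)c2cccc(C(F)(F)F)c2)cc1N1Cc2cnc(OC3CCN(C(=O)OC(C)(C)C)CC3)nc2N(C)C1=O`, in an ADME assay on BaF3 cells (Mus musculus) for antiproliferative activity, read by CellTiter-Glo and CCK-8 assay, with a stated time of 72 h (a higher number here means a weaker inhibitor of growth, a lower number a stronger inhibitor of growth), gives > 10000 nM, which is a limit of the assay and not a number.
Compound 2, `Cc1cc(C)cc(C(=O)Nc2ccc(C)c(N3Cc4cnc(Nc5ccc(C)c(N)c5)nc4N(C)C3=O)c2)c1`, in this assay gives > 10000 nM, again a limit rather than a number.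
Compound 3, `Cc1ccc(Nc2ncc3c(n2)N(C)C(=O)N(c2cc(NC(=O)c4cc(C(C)(C)C)cc(C(C)(C)C)c4)ccc2C)C3)cc1N`, in this assay gives > 10000 nM, also a limit.

Compound 1 stands exactly where every measured compound stands: the limit of > 10000 nM in this assay, at which 3 of the 3 values shown sit. Among the measured compounds shown here, none of the three gives a number, so no ordering among them can be read, and no step between compounds that differ in one place is available to learn from.

Compound 4, `Cc1ccc(NC(=O)c2cccc(C(F)(F)F)c2)cc1N1Cc2cnc(OC3CCNCC3)nc2N(C)C1=O`, differs from compound 1 in one place: hydrogen in place of tert-butoxycarbonyl on an amine nitrogen in a ring. In plain words, the bulky protecting group on the ring nitrogen is gone and a bare hydrogen sits there instead. For the measured compounds named here, no measured pair shows what such a change does here, so any expectation rests only on the fact that all three measured compounds reach the limit of this assay.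

The step from compound 1 to compound 4 is therefore expected to be an at least 1.2-fold lower number from compound 1 to compound 4 (0.09 log units; that floor lies within the scatter), most likely nothing beyond the usual scatter, with some chance that a real number appears just inside the limit. For compound 4 the expected value in this assay is 8000 nM, within a range from 1500 nM to 30000 nM.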

Compound 4, concentration for 50% growth inhibition: > 10000 nM
Compound 4: no number, only a limit; the forecaster's own chance of this, stated with the estimate: 55%; middle value at least 1.2-fold (0.09 log units) away from the limit.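

In this assay compound 4 gives > 10000 nM, which is a limit of the assay and not a number. Compound 1 also sits at a limit, so no step can be read between compound 1 and compound 4. The compounds shown leave open whether hydrogen in place of tert-butoxycarbonyl changes growth inhibition at all, and what would give a real number: the limit of > 10000 nM in this assay, at which 4 of the 4 values shown sit.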